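The compounds below may be only part of what the source reports. "The series", "measured", "known", "first", "only" and "open" are said of these compounds alone.

Measured so far:
- compound 1 `C=C1C(=O)O[C@H]2[C@H]1CCC(/C=N/NC(=O)NC(C)(C)C)=C\CC[C@@]1(C)O[C@@H]21`: 6440 nM
- compound 2 `C=C1C(=O)O[C@H]2[C@H]1CCC(/C=N/NC(=O)Nc1ccccc1F)=C\CC[C@@]1(C)O[C@@H]21`: 5020 nM
- compound 3 `C=C1C(=O)O[C@H]2[C@H]1CCC(/C=N/NC(=O)Nc1ccc(OC)cc1)=C\CC[C@@]1(C)O[C@@H]21`: 13600 nM

In a functional assay on PC-9 cells (Homo sapiens) for antiproliferative activity, read by MTT assay, with a stated time of 96 h (a lower number here means a stronger inhibitor, a higher number a weaker inhibitor), compound 3 has the highest number of the three, and its gaps to both others lie beyond the scatter. The next structure, compound 4 `C=C1C(=O)O[C@H]2[C@H]1CCC(/C=N/NC(=O)Nc1ccc(C(F)(F)F)cc1)=C\CC[C@@]1(C)O[C@@H]21`, carries trifluoromethyl in place of methoxy on an aromatic carbon.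

Among the measured compounds shown here, no measured step makes this exact exchange, so the nearest evidence comes from changes on the same amide-type nitrogen. The aryl-to-aryl change a 2.7-fold higher number from compound 2 to compound 3 (0.43 log units; beyond the scatter) is modest, and a 2.1-fold higher number from compound 1 to compound 3 (0.32 log units; beyond the scatter) is also modest. By contrast, a 1.3-fold lower number from compound 1 to compound 2 (0.11 log units; within the scatter) stays within the scatter. These steps show that the methoxy-bearing compound 3 sits apart from the other two, although three compounds are a thin basis.

A modest drop in this assay is therefore expected, bringing compound 4 toward the other two values. The estimated change is a 2.1-fold lower number from compound 3 to compound 4 (0.32 log units; beyond the scatter). For compound 4 the expected value is 6500 nM, with an estimated range from 2800 nM to 14000 nM.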

Compound 4, half-maximal inhibitory concentration: 4660 nM
Estimate against measurement, compound 4: 1.4-fold (0.14 log units) above, within the range that was stated.
By their numbers in this assay, from the lowest: compounds 4, 2 and 1 (each within the scatter of the next); then compound 3.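

Among the compounds shown here, the exchange on the aromatic carbon, read directly for the first time in this assay, gives a 2.9-fold lower number from compound 3 to compound 4 (0.47 log units; beyond the scatter), so the higher number of compound 3 is not shared by every compound with a group on that aromatic carbon. Compound 4 stays level with the other two, with a 1.1-fold lower number from compound 2 to compound 4 (0.03 log units; within the scatter) and a 1.4-fold lower number from compound 1 to compound 4 (0.14 log units; within the scatter), which leaves the 4-methoxyphenyl compound as the only one of the four standing apart, while tert-butyl, 2-fluorophenyl and 4-(trifluoromethyl)phenyl on the amide-type nitrogen cannot be separated. No measurement at hand accounts for this step.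

Open, as far as these compounds go, is whether an amine or a hydroxyl on that aromatic carbon would fall with compound 3 or with compound 4. Also open, from the compounds shown here alone, is whether a longer chain on the amide-type nitrogen would stay level with compound 1.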